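One Aryl Swap on a Scaffold Without a Number

The source may hold more compounds than are shown below. What is called first, only, known or untested is meant among the compounds shown, and "the series" means these compounds.

Compound 1 `C=CCn1c(=O)/c(=C\c2ccc(Cl)c(Cl)c2)[nH]c(=O)/c1=C\c1ccccc1OC` was examined in a functional assay on HL-60 cells (Homo sapiens) for cytotoxicity, read by CCK-8 assay, with a stated time of 72 h; on this read-out lower numbers stand for stronger inhibition and higher numbers for weaker inhibition; in this assay compound 1 gives "not active" (no number reported), so no single number stands for it. Compound 3 `C=CCn1c(=O)/c(=C\c2cccc(Br)c2)[nH]c(=O)/c1=C\c1cccc(Br)c1` likewise gives "not active" (no number reported) in this assay, a second entry without a number. Only compound 2 `COc1ccccc1/C=c1\c(=O)[nH]/c(=C/c2cccc(Cl)c2Cl)c(=O)n1C` returns a number, giving 200 nM in this assay. Compound 4 `C=CCn1c(=O)/c(=C\c2cc(F)ccc2C)[nH]c(=O)/c1=C\c1ccccc1OC` has not been measured yet. It differs from compound 1 in one place: 5-fluoro-2-methylphenyl in place of 3,4-dichlorophenyl on a double-bonded chain carbon bound to an aromatic carbon. For the measured compounds named here, no measured pair differs only here, so the size of this step is unknown; with compound 1 and compound 3 both reported without a number, the expectation is that this change does not carry compound 4 beyond the scatter into clearly measurable potency. Compound 4 is therefore expected at 10000 nM, within a range from 1500 nM to 60000 nM, and quite possibly only as a limit.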

Compound 4, half-maximal inhibitory concentration: 2600 nM
Beside the measured number, compound 4's estimate is 3.8-fold (0.59 log units) above it; the range from low to high includes it.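

For the compounds shown here, compound 1 carries no number, so no step from it to compound 4 can be read. The compounds shown leave open how far 5-fluoro-2-methylphenyl in place of 3,4-dichlorophenyl shifts potency, and no available evidence bears on this result.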